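The source may hold more compounds than are shown below. What is called first, only, known or untested is meant among the compounds shown, and "the series" means these compounds.

Of the compounds shown here, three have so far been measured in a functional assay on MGC-803 cells (Homo sapiens) for cytotoxicity, read by MTT assay, with a stated time of 48 h; on this read-out higher numbers stand for weaker inhibition and lower numbers for stronger inhibition. Compound 1 `CC1=NN(C(=O)c2ccc(C)cc2)C(c2cc(Br)cc(Br)c2O)C1` gives 56500 nM in that assay. Compound 2 `CC1=NN(C(=O)CN2CCCC2)C(c2ccccc2O)C1` gives 17900 nM in this assay. Compound 3 `O=C(c1ccccc1)N1N=C(c2cc3ccccc3oc2=O)CC1c1ccccc1` gives 12700 nM in this assay, the lowest of the three numbers; its gap to compound 2 lies within the usual scatter, while its gap to compound 1 lies beyond it. Compound 4 `O=C(CN1CCC(O)CC1)N1N=C(c2cc3ccccc3oc2=O)CC1c1ccccc1` has not yet been measured in this assay. It differs from compound 3 in one place: (4-hydroxypiperidin-1-yl)methyl in place of phenyl on a carbonyl carbon. No measured pair among these compounds shows this change on its own, so there is no step to draw on. Compound 2 does carry a ring-bearing methyl group on its carbonyl carbon, but on a different core, so only its value and that of compound 3 can be set side by side, and those two numbers lie within the scatter of each other. On this footing the step is expected to be small, in either direction, and not beyond the scatter, so that a 1.0-fold higher number from compound 3 to compound 4 (0.01 log units; within the scatter) is the expectation. Compound 4 is therefore estimated at 13000 nM in this assay, with a range from 4500 nM to 40000 nM.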

Compound 4, half-maximal inhibitory concentration: "not active" (no number reported)
No number was reported for compound 4, and the estimate cannot be compared.
By their numbers in this assay, from the lowest: compounds 3 and 2 (each within the scatter of the next); then compound 1.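

In this assay, within the data shown here, compound 4 is reported as not active, with no number given, so no step from compound 3 to compound 4 can be read. No evidence at hand bears on this result. The compounds shown leave open how far (4-hydroxypiperidin-1-yl)methyl in place of phenyl on the carbonyl carbon moves the number.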